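This account rests on a few compounds, and the source may have more. Where it says the series, first, only, none or still open, it means among the compounds named here.

Measured so far in a functional assay on the whole organism (Tail, strain ICR) with Mus musculus as the target, in the tail flick test, with a stated time of 60 min, at a dose of 25 umol/kg by the oral route; on this read-out higher numbers stand for a stronger effect at the one dose given and lower numbers for a weaker effect:

- compound 1, `C[C@H](NC(=O)CN(c1nc(Cl)nc2[nH]cnc12)C1CC1)C(=O)OCc1ccccc1`: 64.3%
- compound 2, `O=C(CN(c1ncnc2c1ncn2C1CCCCO1)C1CC1)N[C@@H](CCC(=O)OCc1ccccc1)C(=O)OCc1ccccc1`: 34.7%
- compound 3, `O=C(OCc1ccccc1)[C@@H]1CCCN1C(=O)CN(c1ncnc2c1ncn2C1CCCCO1)C1CC1`: 36.7%

Compound 1 holds the highest of the three numbers in this assay. Its nearest neighbour is compound 3, whose number lies lower by a gap beyond the scatter, and compound 2 lies lower still, also beyond the scatter. Among the compounds with values here, compounds 2 and 3 differ from compound 1 in more than one place, so no single step between measured compounds can be read from these three.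

The next compound, compound 4, `NCCCC[C@H](NC(=O)CN(c1nc(Cl)nc2[nH]cnc12)C1CC1)C(=O)OCc1ccccc1`, is not yet measured. It keeps the core of compound 1 and differs from it in one place: 3-aminopropyl in place of hydrogen on a saturated chain carbon, two bonds along the chain from an amide-type nitrogen and a carbonyl carbon

Within the data shown here, with no step between measured compounds at hand, the size of the step from compound 1 to compound 4 has to be guessed from the change alone. The working expectation is a moderate fall, a number 16.3 percentage points lower from compound 1 to compound 4 (beyond the scatter), somewhat beyond the scatter but leaving compound 4 still a clear response rather than an inactive one. On that basis compound 4 is expected to give 48% in this assay, with a range from 25% to 72%.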

Compound 4, a percentage reported as activity, at one dose (the size of the read-out at that dose, not a potency): 41.2%
Beside the measured number, compound 4's estimate is 6.8 percentage points above it, and the stated range covers the measured number.
By their numbers in this assay, from the lowest: compounds 2, 3 and 4 (each within the scatter of the next); then compound 1.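

In this assay, within the data shown here, this is the first single-place step: a number 23.1 percentage points lower from compound 1 to compound 4 (beyond the scatter) when 3-aminopropyl replaces hydrogen on a saturated chain carbon, two bonds along the chain from an amide-type nitrogen and a carbonyl carbon. This position is therefore sensitive to the change, yet compound 4 still gives 41.2% at the one dose tested, so the longer amine-bearing chain removes part of the response and not all of it. Nothing measured here accounts for the size of this step.

With one step, the contribution of the terminal amine cannot be separated from that of chain length. As far as these compounds go, the outcome with a plain butyl chain, a shorter aminomethyl group or a carboxylic acid at the chain end remains open.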